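Swapping nitro for chloro on a dienone ether

This account rests on a few compounds, and the source may have more. Where it says the series, first, only, none or still open, it means among the compounds named here.

Compound 1 `O=C(/C=C/c1ccc(Cl)c([N+](=O)[O-])c1)/C=C/c1ccccc1Oc1ncnc2ccc(Cl)cc12` gives 70.2% in a functional assay on MGC-803 cells (Homo sapiens) for inhibition, read by MTT assay, with a stated time of 72 h, tested at 10 uM; a higher number here means more inhibition of growth at the concentration tested, a lower number less inhibition of growth.
Compound 2 `O=C(/C=C/c1ccc(Oc2ncnc3ccc(Cl)cc23)cc1)/C=C/c1ccc(Cl)c([N+](=O)[O-])c1` gives 66.2% in this assay.
Compound 3 `O=C(/C=C/c1ccc(Cl)c(Cl)c1)/C=C/c1ccccc1Oc1ncnc2ccc(Cl)cc12` gives 56.7% in this assay.

Compound 1 and compound 2 share the same atoms joined differently; the difference between the two cores is not broken down here. Their values lie within the scatter of each other, so nothing can be read into the gap. Compound 3 is made from compound 1 by one change, (chloro in place of nitro on an aromatic carbon), and the step was a number 13.5 percentage points lower from compound 1 to compound 3 (beyond the scatter).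

Compound 4 `O=C(/C=C/c1ccc(Oc2ncnc3ccc(Cl)cc23)cc1)/C=C/c1ccc(Cl)c(Cl)c1` is not yet measured. It stands to compound 2 as compound 3 stands to compound 1: the change is chloro in place of nitro on an aromatic carbon, the same change in the same surroundings. If the step repeats on the core of compound 2, the expected step is a number 13.2 percentage points lower from compound 2 to compound 4 (beyond the scatter), resting on the single measured step of a number 13.5 percentage points lower from compound 1 to compound 3 (beyond the scatter). Because that rests on one pair only, the range is kept wide. Compound 4 is therefore expected to give about 53% in this assay.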

Compound 4, percent growth inhibition at one concentration: 50.5%
The estimate for compound 4 lay 2.5 percentage points above the measured number, within the range that was stated.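

On the core of compound 2, the change from 4-chloro-3-nitrophenyl to 3,4-dichlorophenyl gave a number 15.7 percentage points lower from compound 2 to compound 4 (beyond the scatter) in this assay, so the drop seen on the core of compound 1 appeared here as well. Within this small set, the step carried from one core to the other, and its size on the two cores cannot be told apart: the same change on two cores in this assay, a number 13.5 percentage points lower (beyond the scatter) from compound 1 to compound 3 and a number 15.7 percentage points lower (beyond the scatter) from compound 2 to compound 4, 2.2 percentage points apart, within the scatter of two such steps. Within the data shown here, this rests on only two matched pairs, tested in one cell line at one concentration, so it does not show that the step would hold on any further core, and it does not explain why the chloro compounds inhibit growth less than their nitro partners.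

The compounds shown leave open whether an amine, a carboxylic acid or a methoxy group in place of the nitro would behave more like the nitro or like the chloro. They also leave open whether the same step would appear if a longer chain replaced the ether link in the core.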